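The source may hold more compounds than are shown below. What is called first, only, known or untested is meant among the compounds shown, and "the series" means these compounds.

In a functional assay (a lower number here means a stronger inhibitor, a higher number a weaker inhibitor), compound 1 `CC(C)=CCOc1ccc2c(c1)OC(c1ccccc1F)CC2=O` gives 6360 nM, and compound 2 `CC(C)=CCOc1cc(O)c2c(c1)OC(c1ccccc1F)CC2=O` gives 5300 nM. Among the compounds with values here, these two numbers lie within the scatter of each other, so compound 2 cannot be separated from the only other measured compound. Compound 3 `CC(C)=CCOc1cc(O)c2c(c1)OC(c1cccc(Cl)c1)CC2=O` differs from compound 2 in one group: 3-chlorophenyl in place of 2-fluorophenyl on a saturated ring carbon. Put simply, 3-chlorophenyl stands in place of 2-fluorophenyl on a saturated ring carbon, next to the ring oxygen. Within the data shown here, the only measured step, a 1.2-fold lower number from compound 1 to compound 2 (0.08 log units; within the scatter), is hydroxy in place of hydrogen on an aromatic carbon. Among the measured compounds shown here, it lies elsewhere in the molecule, so it says little about this swap, and no measured step changes this group. No step beyond the scatter can therefore be predicted in this assay, and no direction is favoured. The expected change is a 1.2-fold lower number from compound 2 to compound 3 (0.07 log units; within the scatter), with real uncertainty around it. For compound 3 the estimated value is 4500 nM, within an expected range of 1500 nM to 15000 nM.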

Compound 3, half-maximal inhibitory concentration: 6060 nM
Estimate against measurement, compound 3: 1.3-fold (0.13 log units) below; low and high end bracket the measured number.
By their numbers in this assay, from the lowest: compounds 2, 3 and 1 (each within the scatter of the next).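

In this assay, putting 3-chlorophenyl in place of 2-fluorophenyl on the saturated ring carbon gives a 1.1-fold higher number from compound 2 to compound 3 (0.06 log units; within the scatter). Within the data shown here, this is the first measured change at this place, and it shows that these two halogen-bearing phenyl groups cannot be told apart here, since the step stays within the scatter. Nothing measured here offers an explanation for this result.

The swap alters both the halogen and where it sits on the phenyl ring, so the compounds shown cannot separate these two changes, and a phenyl group with no halogen remains an open comparison. From the compounds shown here alone, it also remains open whether a phenyl ring is needed at this place at all, or whether a methyl group, or a phenyl ring carrying an amine or a carboxylic acid, would move the number beyond the scatter.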